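Swapping one aryl group on a sulfur-containing ring

A few compounds are considered here, and "the series" means these few. Any claim that something is new, unique, unknown or untested is made for them only; others in the source may bear on it.

Three compounds share a long tail and a five-membered non-aromatic ring with 1 nitrogen and 1 sulfur, or a close relative of it, and all were tested in a functional assay on HOS cells (Homo sapiens) for inhibition, read by CCK-8 assay, with a stated time of 72 h, tested at 1 uM; on this read-out higher numbers stand for more inhibition at the one concentration tested (going by the name of the read-out) and lower numbers for less inhibition. Compound 1, `COc1cccc(OC)c1N1C(=O)CSC1c1cccc(C(=O)NCCCCc2ccccc2)c1`, gives 80%, which places it second highest of the three numbers. Compound 3, `CCOc1ccccc1N1C(=O)C(C)SC1c1cccc(C(=O)NCCCCc2ccccc2)c1`, gives 82%, a value within the usual scatter of that for compound 1, so the two cannot be told apart. Compound 2, `O=C(NCCCCc1ccccc1)c1cccc(C2OCC(=O)N2c2cccc(F)c2)c1`, gives 29%, far below the other two and beyond the scatter.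

The next compound, compound 4, `COc1ccc(F)cc1N1C(=O)CSC1c1cccc(C(=O)NCCCCc2ccccc2)c1`, differs from compound 1 in a single spot: 5-fluoro-2-methoxyphenyl in place of 2,6-dimethoxyphenyl on an amide-type nitrogen in a ring. Going by the values given here, no measured pair shows this exact swap, so the size of the step is an open question. Compound 3 shows that a single alkoxy group on that aryl ring still gives 82%, which makes a large loss seem unlikely, while compound 2 shows that strong drops do occur in this series.

A modest downward step a number 10 percentage points lower from compound 1 to compound 4 (within the scatter) is expected, because compound 1 gives 80%. Compound 4 is therefore estimated at 70%, with a plausible range from 45% to 88%.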

Compound 4, a percentage reported as inhibition, at one concentration (the size of the read-out at that concentration, not a potency): 46%
The estimate for compound 4 lay 24 percentage points above the measured number; measured number inside the range.
By their numbers in this assay, from the lowest: compound 2; then compound 4; then compounds 1 and 3 (each within the scatter of the next).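

Going by these compounds alone, putting 5-fluoro-2-methoxyphenyl in place of 2,6-dimethoxyphenyl on the amide-type nitrogen in a ring gives, in this assay, a number 34 percentage points lower from compound 1 to compound 4 (beyond the scatter) and so provides the first direct evidence that this position is sensitive to the choice of aryl group. The tail and the rest of the core stay the same across this pair, yet the swap makes two changes at once: one methoxy group leaves and a fluorine enters, taking the group from 2 hydrogen-bond acceptors to 1. Nothing measured here gives a reason for the drop.

The compounds shown leave open whether the step follows the lost methoxy group, the added fluorine or both, and a plain 2-methoxyphenyl group on that nitrogen would help to separate these possibilities. Also open, from the compounds shown here alone, is how other groups on this aryl ring, such as a chlorine, a nitrile or a dimethylamino group, would read in this assay on the core of compound 1.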